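The source may hold more compounds than are shown below. What is called first, only, known or untested is meant among the compounds shown, and "the series" means these compounds.

Measured so far:
compound 1 `Cc1c(Nc2nc(N)c3c(C#N)c(N4CCC[C@H]4C)n(C)c3n2)cnn1C`: 43 nM
compound 2 `Cn1c(N2CCCC2)c(C#N)c2c(N)ncnc21`: 1910 nM
compound 3 `Cc1c(Nc2nc(N)c3c(C#N)c(N4CCC[C@H]4C)n(C)c3n2)cnn1[C@H]1CCOC1`: 14 nM

In an assay on isolated protein for inhibition of Leucine-rich repeat serine/threonine-protein kinase 2 variant G2019S (Homo sapiens), read by TR-FRET and LanthaScreen, with stated times of 50 min and 30 min, in the presence of a further agent that is not named here (a lower number here means a stronger inhibitor, a higher number a weaker inhibitor), compound 1 gives 43 nM, the second highest of the three numbers. Nearest stands compound 3 with 14 nM, furthest compound 2 with 1910 nM. Within the data shown here, the only single-point step in the set is a 3.1-fold lower number from compound 1 to compound 3 (0.49 log units; beyond the scatter).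

Compound 4 `C[C@@H]1CCCN1c1c(C#N)c2c(N)nc(N)nc2n1C` differs from compound 1 by hydrogen in place of 1,5-dimethyl-1H-pyrazol-4-yl on a nitrogen on an aromatic ring; cut one bond further out, the difference reads (1,5-dimethyl-1H-pyrazol-4-yl)amino to amino. Among the measured compounds shown here, no measured step covers this change. The step from compound 1 to compound 3 alters only the substituent on the aromatic nitrogen of the group that leaves here, so it says nothing about removing that group as a whole. For the measured compounds named here, compound 2 lacks the (1,5-dimethyl-1H-pyrazol-4-yl)amino group, but it also differs from compound 4 in the pyrrolidine part and carries hydrogen where compound 4 carries amino, so its number cannot be split into single steps; it shows only that a core without the group gives a much higher number than compound 1.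

The expectation is therefore a large rise in the number, with wide uncertainty. The estimate for compound 4 is 1500 nM (range 350 nM to 6500 nM), a step of a 35-fold higher number from compound 1 to compound 4 (1.54 log units; beyond the scatter) being expected.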

Compound 4, half-maximal inhibitory concentration: 217 nM
Compound 4: middle estimate off by 6.9-fold (0.84 log units), on the high side; the measured number lies below the stated range.
By their numbers in this assay, from the lowest: compound 3; then compound 1; then compound 4; then compound 2.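

In this assay, the whole 1,5-dimethyl-1H-pyrazol-4-yl group can leave the nitrogen on the aromatic ring, with hydrogen entering, at the cost of only a 5.0-fold higher number from compound 1 to compound 4 (0.70 log units; beyond the scatter). The group therefore accounts for only a modest part of the number of compound 1, and the amino form of the core stays within a modest step of it, a step of the same class as the change on the aromatic nitrogen of the pyrazole, a 3.1-fold lower number from compound 1 to compound 3 (0.49 log units; beyond the scatter). Nothing at hand accounts for why removing this group costs so little.

Among these compounds, the single step leaves open how the number responds to groups of intermediate size on this nitrogen, such as a methyl, an acetyl or a phenyl ring, so it is unclear whether the aromatic ring of the 1,5-dimethyl-1H-pyrazol-4-yl group matters more than its mere presence. Also open, going by these compounds, is whether the lower number brought by oxolan-3-yl carries over to other groups on the aromatic nitrogen of the pyrazole, such as an ethyl or a piperidin-4-yl.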